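Exchanging the side group on the carbonyl of compound 3

This account rests on a few compounds, and the source may have more. Where it says the series, first, only, none or still open, it means among the compounds named here.

In a functional assay on PC-3 cells (Homo sapiens) for inhibition, read by MTT assay (a lower number here means a stronger inhibitor, a higher number a weaker inhibitor), compound 3 `CN1CC(NC(=O)c2cccc(Nc3nc4nc5c(cnn35)CCCCC(=O)Nc3cccc(c3)N4)c2)C1` gives 330 nM and holds the higher of the two numbers available. Compound 1 `CCN(CC)C1CCN(C(=O)c2cccc(Nc3nc4nc5c(cnn35)CCCCC(=O)Nc3cccc(c3)N4)c2)C1` gives 140 nM as its result. Compound 2 `CN1CCC(N(C)C(=O)c2cccc(Nc3nc4nc5c(cnn35)CCCCC(=O)Nc3cccc(c3)N4)c2)CC1` has the entry "not determined" (no result reported) and so offers no guide here.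

Compound 4 `CN(C)C1CCN(C(=O)c2cccc(Nc3nc4nc5c(cnn35)CCCCC(=O)Nc3cccc(c3)N4)c2)C1` carries 3-(dimethylamino)pyrrolidin-1-yl in place of (1-methylazetidin-3-yl)amino on a carbonyl carbon, and 3-(dimethylamino)pyrrolidin-1-yl in place of (1-methylazetidin-3-yl)amino on a carbonyl carbon gives the full count of that change.

For the measured compounds named here, the one measured step that bears on this is a 2.4-fold higher number from compound 1 to compound 3 (0.37 log units; beyond the scatter) with (1-methylazetidin-3-yl)amino in place of 3-(diethylamino)pyrrolidin-1-yl on a carbonyl carbon. That step was modest. Going by the values given here, the group entering now differs from the one lost there only in dimethylamino for diethylamino, so a modest step toward a lower number is expected, though no measured pair isolates that difference. The expected change is a 2.1-fold lower number from compound 3 to compound 4 (0.31 log units; beyond the scatter) on this estimate. Compound 4 is estimated at 160 nM with 70 nM to 380 nM as the expected range.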

Compound 4, half-maximal inhibitory concentration: 230 nM
Compound 4: middle estimate off by 1.4-fold (0.16 log units), on the low side; measured number inside the range.
By their numbers in this assay, from the lowest: compounds 1, 4 and 3 (each within the scatter of the next, the first and the last beyond it).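

In this assay the exchange on the carbonyl carbon comes to a 1.4-fold lower number from compound 3 to compound 4 (0.16 log units; within the scatter) even though a four-membered ring gives way to a five-membered ring and the hydrogen-bond donor is lost, so this whole change gives no shift that can be told from the scatter. Replacing diethylamino with dimethylamino on a saturated ring carbon gives a 1.6-fold higher number from compound 1 to compound 4 (0.22 log units; within the scatter) and is likewise no readable change, which places compound 4 within the scatter of both the others, although compound 1 and compound 3 remain apart beyond it. Nothing available here accounts for these numbers. All the numbered side groups keep an amine in a saturated ring, so a morpholine ring or a carboxylic acid on that carbonyl carbon remains an open case. Whether a longer chain such as dipropylamino would set a compound apart from compound 1 also stays unanswered.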